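Compound 3: expected stability after the change from compound 2

A few compounds are considered here, and "the series" means these few. Any claim that something is new, unique, unknown or untested is made for them only; others in the source may bear on it.

Compound 1 `c1ccc2c(c1)CN[C@H](CN(CCCN1CCNCC1)[C@H]1CCCc3cccnc31)C2` gives 88%
Compound 2 `c1ccc2c(c1)CN[C@@H](CN(CCCN1CCNCC1)[C@H]1CCCc3cccnc31)C2` gives 92%

In an ADME assay on microsomes from liver (Mus musculus) for metabolic stability, read by LC-MS, with a stated time of 10 min, tested at 0.5 uM (on this read-out lower numbers stand for a less stable compound and higher numbers for a more stable compound), compound 2 gives 92% and lies within the scatter of compound 1. Compound 3 `c1cnc2c(c1)CCC[C@@H]2N(CCCN1CCNCC1)Cc1cc2ccccc2cn1` is unmeasured and carries isoquinolin-3-yl in place of 1,2,3,4-tetrahydroisoquinolin-3-yl on a saturated chain carbon bound to an amine nitrogen. Within the data shown here, the only measured step, a number 4 percentage points higher from compound 1 to compound 2 (within the scatter), involves configuration alone the fact that compounds 1 and 2 differ only in the configuration as drawn and offers only weak guidance for this replacement. With compound 2 at 92% little room remains upward, so any real move is expected to be downward. The expected step is a number 12 percentage points lower from compound 2 to compound 3 (beyond the scatter) in this assay. The estimate for compound 3 is 80%, with a range of 58% to 97%.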

Compound 3, percent of the compound remaining: 74%
Beside the measured number, compound 3's estimate is 6 percentage points above it, and the stated range covers the measured number.
By their numbers in this assay, from the lowest: compound 3; then compounds 1 and 2 (each within the scatter of the next).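

In this assay, isoquinolin-3-yl in place of 1,2,3,4-tetrahydroisoquinolin-3-yl gives a number 18 percentage points lower from compound 2 to compound 3 (beyond the scatter) and a number 14 percentage points lower from compound 1 to compound 3 (beyond the scatter). This position therefore responds to a change of the group itself, which the earlier pair could not show: the fact that compounds 1 and 2 differ only in the configuration as drawn. The change removes the hydrogen-bond donor and the defined stereocentre and makes the nitrogen-bearing ring aromatic, all in one step.

Which of these differences carries the loss stays open. Also open, as far as these compounds go, is how a phenyl group or a saturated piperidin-2-yl group would read at this place.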